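The source may report more compounds than this note shows. Statements on the series, on what has been measured and on what is new or still open speak of the compounds shown alone.

Compound 1 (`Cc1cn(C2OC(CO[Si](C)(C)C(C)(C)C)C3(OS(=O)(=O)C=C3N)C2O[Si](C)(C)C(C)(C)C)c(=O)n(CCCNC(=O)[C@@H]2CCCN2C(=O)[C@@H](N)C(C)C)c1=O`), compound 2 (`Cc1cn(C2OC(CO[Si](C)(C)C(C)(C)C)C3(OS(=O)(=O)C=C3N)C2O[Si](C)(C)C(C)(C)C)c(=O)n(CCCNC(=O)[C@@H]2CCCN2C(=O)[C@H](C)N)c1=O`) and compound 3 (`Cc1cn(C2OC(CO[Si](C)(C)C(C)(C)C)C3(OS(=O)(=O)C=C3N)C2O[Si](C)(C)C(C)(C)C)c(=O)n(CCCNC(=O)[C@H](C)NC(=O)[C@@H](N)C(C)C)c1=O`) share one core and differ only at the end of one chain. In a functional assay on MT4 cells (Homo sapiens) for antiproliferative activity (on this read-out higher numbers stand for lower toxicity in this test and lower numbers for higher toxicity in this test), compound 1 gives 11000 nM, compound 2 gives 20000 nM and compound 3 gives 22000 nM. All three numbers lie within the scatter of one another, so compound 3 stands level with the other two.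

Compound 4 (`Cc1cn(C2OC(CO[Si](C)(C)C(C)(C)C)C3(OS(=O)(=O)C=C3N)C2O[Si](C)(C)C(C)(C)C)c(=O)n(CCCNC(=O)[C@H]2CCCN2C(=O)[C@@H](N)C(C)C)c1=O`) keeps the core but alters that chain end: 1-((1-amino-2-methylpropyl)carbonyl)pyrrolidin-2-yl in place of 1-(((1-amino-2-methylpropyl)carbonyl)amino)ethyl on a carbonyl carbon. The exchange sits on a carbonyl carbon whose other neighbour is an amide-type nitrogen.

The closest evidence is the same exchange of named groups run in the opposite direction, which gave a 2.0-fold higher number from compound 1 to compound 3 (0.30 log units; within the scatter). The two related changes gave a 1.1-fold higher number from compound 2 to compound 3 (0.04 log units; within the scatter) and a 1.8-fold higher number from compound 1 to compound 2 (0.26 log units; within the scatter). None of these steps leaves the scatter, so no real shift is expected in this assay.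

The expected step is a 1.5-fold lower number from compound 3 to compound 4 (0.17 log units; within the scatter), which would still be a small one.

For compound 4 the estimated value is 15000 nM, with an expected range from 8000 nM to 30000 nM.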

Compound 4, half-maximal cytotoxic concentration: 22000 nM
Estimate against measurement, compound 4: 1.5-fold (0.17 log units) below; the range from low to high includes it.
By their numbers in this assay, from the lowest: compounds 1, 2, 3 and 4 (each within the scatter of the next).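

In this assay, putting the ring-bearing 1-((1-amino-2-methylpropyl)carbonyl)pyrrolidin-2-yl on the carbonyl carbon gives no change at the digits printed from compound 3 to compound 4 (within the scatter), so the open-chain and ring forms of this chain end cannot be told apart here. Exchanging the chain end of compound 2 gives a 1.1-fold higher number from compound 2 to compound 4 (0.04 log units; within the scatter), which adds a second reading that stays within the scatter. The newest information concerns spatial arrangement, since the step of a 2.0-fold higher number from compound 1 to compound 4 (0.30 log units; within the scatter) tests a single stereocentre at a saturated ring carbon and it too stays within the scatter, with one caution on how that pair is drawn: the fact that one of compounds 1 and 4 is drawn with a defined configuration and the other without, at the place where they differ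

From the compounds shown here alone, what remains open is whether any chain end can move this number beyond the scatter. A carboxylic acid in place of the terminal amine, or a longer chain, might read differently.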